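The compounds below may be only part of what the source reports. "The series", "measured", "known", "first", "only" and "open" are said of these compounds alone.

Compound 3, `O=c1cc(N2CCNCC2)n(Cc2ccccc2)c2ccnn12`, is the starting point. In an ADME assay on isolated protein for inhibition of Dipeptidyl peptidase 9 (Homo sapiens), read by fluorescence, with a stated time of 10 min (on this read-out lower numbers stand for stronger inhibition and higher numbers for weaker inhibition), compound 3 gives > 100000 nM, which is a limit of the assay and not a number. Compound 2, `Cc1ccc(Cn2c(N3CCNCC3)cc(=O)n3nccc23)cc1`, gives > 100000 nM in this assay, again a limit. Compound 1, `N#Cc1ccccc1Cc1c(Cl)nc2ccnn2c1N1CCC[C@@H](N)C1`, gives > 100000 nM, also a limit. Among the measured compounds shown here, the one measured step, a step that the two limits leave unreadable from compound 2 to compound 3, cannot be read, since every value shown sits at the limit of > 100000 nM in this assay, at which 3 of the 3 values shown sit. Compound 4, `O=c1cc(N2CCNCC2)n(Cc2ccccc2[N+](=O)[O-])c2ccnn12`, differs from compound 3 by nitro in place of hydrogen on an aromatic carbon. For the measured compounds named here, no measured step touches a nitro group, so nothing in these data supports a shift beyond the scatter. Compound 4 is therefore expected to give about 300000 nM, with a range from 50000 nM to 2000000 nM, a step that the limit leaves unreadable from compound 3 to compound 4 that is estimated to stay within the scatter.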

Compound 4, half-maximal inhibitory concentration: > 100000 nM
Compound 4 gave a limit, no number (the forecaster's own chance of this, stated with the estimate: 85%); the middle value lies beyond the limit too.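

No new step can be read from compound 3 to compound 4, since both values are limits and not numbers: the limit of > 100000 nM in this assay, at which 4 of the 4 values shown sit.

The compounds shown leave open whether nitro in place of hydrogen on an aromatic carbon changes the inhibition at all.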